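The source may hold more compounds than are shown below. What is called first, only, known or untested is meant among the compounds shown, and "the series" means these compounds.

Compound 1 `CC(C)C(/C=C1\NC(=O)NC1=O)c1ccc(-c2ccc3cccc(F)c3c2)[nH]c1=O` gives 43 nM in an assay on membranes from Chem-1 cells for displacement of a labelled ligand from prostaglandin E2 receptor EP3 subtype (Homo sapiens), read by scintillation counting, with a stated time of 2 h; on this read-out lower numbers stand for stronger inhibition and higher numbers for weaker inhibition. Compound 2 `CC(C)C(c1ccc(-c2ccc3cccc(F)c3c2)[nH]c1=O)C1NC(=O)NC1=O` gives 50 nM in this assay, so the two numbers lie within the scatter of each other and compound 2 is not separated from compound 1 on this read-out. Within the data shown here, the only step so far, a 1.2-fold higher number from compound 1 to compound 2 (0.07 log units; within the scatter), exchanges the ring at the saturated chain carbon bound to an aromatic carbon and a saturated chain carbon and leaves the number essentially where it was.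

Compound 3 `CC(C)C(c1ccc(-c2ccc3cccc(F)c3c2)[nH]c1=O)C1SC(=O)NC1=O` carries the change (2,4-dioxo-1,3-thiazolidin-5-yl in place of 2,5-dioxoimidazolidin-4-yl on a saturated chain carbon bound to an aromatic carbon and a saturated chain carbon). Among the measured compounds shown here, this bears on the same position as the step from compound 1 to compound 2, which stayed within the scatter; no measured step exchanges a ring nitrogen for sulfur, so nothing here predicts a shift beyond the scatter. The expected step is a 1.2-fold higher number from compound 2 to compound 3 (0.08 log units; within the scatter), with no direction claimed beyond the scatter. For compound 3 the estimate in this assay is 60 nM, with a range from 25 nM to 150 nM.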

Compound 3, inhibition constant: 25 nM
Compound 3: middle estimate off by 2.4-fold (0.38 log units), on the high side, and the stated range covers the measured number.
By their numbers in this assay, from the lowest: compounds 3, 1 and 2 (each within the scatter of the next).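

In this assay, placing 2,4-dioxo-1,3-thiazolidin-5-yl in place of 2,5-dioxoimidazolidin-4-yl on the saturated chain carbon gives a 2.0-fold lower number from compound 2 to compound 3 (0.30 log units; within the scatter), so this position accepts a ring containing sulfur, with one hydrogen-bond donor exchanged for an acceptor, without leaving the scatter. The larger group of compound 1 and the ring of compound 3 are also not separated, with a 1.7-fold lower number from compound 1 to compound 3 (0.24 log units; within the scatter). No supporting measurement bears on what lies behind these small steps.

From the compounds shown here alone, all three compounds carry a five-membered non-aromatic ring at this position, so it remains open how the number would respond to an open-chain group such as a carboxylic acid or an amine. A methyl group on the ring nitrogen of the 2,4-dioxo-1,3-thiazolidin-5-yl ring is also an open case.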